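Swapping thiophen-3-yl for thiophen-2-yl in compound 2

The source may report more compounds than this note shows. Statements on the series, on what has been measured and on what is new or still open speak of the compounds shown alone.

In a functional assay on cells (Cancer cell lines, Homo sapiens) for inhibition (a higher number here means a weaker inhibitor of growth, a lower number a stronger inhibitor of growth), compound 1 (`Cc1cn2c(/C=N/NC(=N)N)c(-c3ccsc3)nc2s1`) gives 11000 nM as its measured value. Compound 2 (`N=C(N)N/N=C/c1c(-c2ccsc2)nc2n1CCS2`) gives 14500 nM and so lies within the scatter of compound 1, which means the two cannot be put in order. Compound 3 (`N=C(N)N/N=C/c1c(-c2cccs2)nc2n1CCS2`) has not yet been measured. It differs from compound 2 in one place, with thiophen-2-yl in place of thiophen-3-yl on an aromatic carbon. The two have the same atoms, joined differently. Within the data shown here, no measured pair shows what such a swap does, so the expectation rests only on the two values so far and the small size of the change. In this assay no shift beyond the scatter is expected, in either direction. The estimate means a 1.1-fold lower number from compound 2 to compound 3 (0.05 log units; within the scatter) as the expected step. Compound 3 is estimated at 13000 nM with an expected range from 5500 nM to 30000 nM as the likely span.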

Compound 3, concentration for 50% growth inhibition: 39800 nM
Compound 3: the middle estimate sits 3.1-fold (0.49 log units) below what was measured, outside the stated range (above it).
By their numbers in this assay, from the lowest: compounds 1 and 2 (each within the scatter of the next); then compound 3.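

The earlier compounds shown here carried only thiophen-3-yl at this position, on an aromatic carbon of a five-membered aromatic ring with 2 nitrogen, so they gave no view of how it responds to change. In this assay thiophen-2-yl in place of thiophen-3-yl gives a 2.7-fold higher number from compound 2 to compound 3 (0.44 log units; beyond the scatter) even though the atoms stay the same, so at this position the way the thiophene is joined to the core affects growth inhibition. The data shown offer no measurement that explains this difference.

The compounds shown leave open whether thiophen-2-yl would have the same effect on the core of compound 1. They also leave open how a phenyl ring, a furan-3-yl group or an amine would behave at this position.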